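A few compounds are considered here, and "the series" means these few. Any claim that something is new, unique, unknown or untested is made for them only; others in the source may bear on it.

Of the compounds shown here, three built on a shared core have been tested in a functional assay on the whole organism (strain Swiss albino) with Mus musculus as the target, in the forced swim test, with a stated time of 5 min, at a dose of 0.5 mg/kg by the intraperitoneal route; on this read-out lower numbers stand for less inhibition and higher numbers for more inhibition at the one dose given (going by the name of the read-out). Compound 1 `COc1ccc(-c2cc3cc(C4C(C#N)=C(N)OC5=C4C(=O)CCC5)cc(C(C)C)c3oc2=O)cc1` gives 69.7%. Compound 2 `CCC(C)c1cc(C2C(C#N)=C(N)OC3=C2C(=O)CCC3)cc2cc(-c3ccc(OC)cc3)c(=O)oc12` gives 35.1%, and compound 3 `CCC(C)c1cc(C2C(C#N)=C(N)OC3=C2C(=O)CCC3)cc2cc(-c3cc(OC)c(OC)c(OC)c3)c(=O)oc12` gives 56.1%. Among these three numbers compound 2 stands lowest; the step of a number 21 percentage points higher from compound 2 to compound 3 (beyond the scatter) is modest, while the step of a number 34.6 percentage points lower from compound 1 to compound 2 (beyond the scatter) is large.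

Compound 4 `COc1ccc(-c2cc3cc(C4C(C#N)=C(N)OC5=C4C(=O)CCC5)cc(C(C)(C)C)c3oc2=O)cc1` is the next compound to be measured. It differs from compound 2 only in that (tert-butyl in place of sec-butyl on an aromatic carbon); the two hold the same atoms, joined differently. For the measured compounds named here, only the step of a number 34.6 percentage points lower from compound 1 to compound 2 (beyond the scatter) bears on this change, since it also altered the saturated chain on that aromatic carbon, and it was large; the step of a number 21 percentage points higher from compound 2 to compound 3 (beyond the scatter) concerns another part of the molecule. Because that one relevant step a number 34.6 percentage points lower from compound 1 to compound 2 (beyond the scatter) was large, a sizeable move is expected here as well, most likely upward, though the direction is uncertain. Compound 4 is therefore estimated to give 50% in this assay, within a range from 25% to 75%, which is expected to mean a step of a number 14.9 percentage points higher from compound 2 to compound 4 (beyond the scatter).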

Compound 4, a percentage reported as inhibition, in the whole organism at one dose (the size of the read-out at that dose, not a potency): 30.7%
Compound 4: the middle estimate sits 19.3 percentage points above what was measured, and the stated range covers the measured number.
By their numbers in this assay, from the lowest: compounds 4 and 2 (each within the scatter of the next); then compound 3; then compound 1.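

In this assay, tert-butyl in place of sec-butyl gives a number 4.4 percentage points lower from compound 2 to compound 4 (within the scatter), so at this aromatic carbon these two four-carbon groups cannot be told apart. Adding a methyl to the isopropyl group of compound 1, this time on the chain carbon bound to the aromatic carbon, gives a number 39 percentage points lower from compound 1 to compound 4 (beyond the scatter), which goes the same way as the earlier a number 34.6 percentage points lower from compound 1 to compound 2 (beyond the scatter) and shows that both four-carbon groups read well under the isopropyl group, wherever the extra carbon sits. Nothing measured here explains this drop.

Still open, as far as these compounds go, is how a methyl group, an ethyl group or a straight butyl chain would read at this aromatic carbon. Also open, from the compounds shown here alone, is whether the 3,4,5-trimethoxyphenyl group, which gave a number 21 percentage points higher from compound 2 to compound 3 (beyond the scatter), would change the number in the same way alongside tert-butyl.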